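This account rests on a few compounds, and the source may have more. Where it says the series, first, only, none or still open, it means among the compounds named here.

Two compounds of this series carry numbers in an assay on isolated protein for inhibition of Rho-associated protein kinase 1 (Homo sapiens), tested at 30 uM; on this read-out lower numbers stand for less inhibition and higher numbers for more inhibition at the one concentration tested (going by the name of the read-out). Compound 1 `c1ccc(Oc2ncnc3[nH]cnc23)cc1` gives 16% in this assay. Compound 2 `c1ccc(C[n+]2c[nH]c3ncncc32)cc1` gives 7% in this assay, the lower of the two numbers shown, though its gap to compound 1 stays within the scatter of the method, so no order between the two can be read from them. Among the measured compounds shown here, no step between measured compounds that differ in a single place is available, so nothing is known yet about how one small change shifts this read-out.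

Compound 3 `Fc1ccc(C[n+]2c[nH]c3ncncc32)cc1` is the next member to be measured. It differs from compound 2 in one place: fluoro in place of hydrogen on an aromatic carbon. With both measured numbers at the low end of the scale and close together, the step expected for this assay is small: a number 2 percentage points higher from compound 2 to compound 3 (within the scatter) is estimated, a change not beyond the scatter in either direction. For compound 3 the value expected in this assay is 9%, in the range of 0% to 22%.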

Compound 3, a percentage reported as inhibition, at one concentration (the size of the read-out at that concentration, not a potency): 4%
Compound 3: the middle estimate sits 5 percentage points above what was measured, within the range that was stated.
By their numbers in this assay, from the lowest: compounds 3, 2 and 1 (each within the scatter of the next, the first and the last beyond it).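

Fluoro in place of hydrogen on an aromatic carbon, para to a large group, provides the first single-place step in this series: in this assay the change gives a number 3 percentage points lower from compound 2 to compound 3 (within the scatter). At this position on the six-membered aromatic ring of carbon only, the step therefore shows no shift beyond the scatter and gives no direction for the effect of fluoro. Nothing available bears on the reason for this result.

As far as these compounds go, whether an amine, a carboxylic acid or a longer chain at this same place would move the read-out beyond the scatter stays open. Also open, from the compounds shown here alone, is what fluoro does on the other carbons of that ring, and how these compounds read at any other concentration.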